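A few compounds are considered here, and "the series" means these few. Any claim that something is new, unique, unknown or untested is made for them only; others in the source may bear on it.

Measured compounds:
- compound 1, `O=c1c(Cc2coc3cccc(OCC4CCCCC4)c3c2=O)coc2ccccc12`, gives 4230 nM in a functional assay on ACHN cells (Homo sapiens) for antiproliferative activity, read by XTT assay; on this read-out higher numbers stand for weaker inhibition and lower numbers for stronger inhibition.
- compound 2, `O=c1c(/C=C/c2coc3ccccc3c2=O)coc2ccccc12`, reaches only the limit of this assay, > 10000 nM.

Going by the values given here, compound 1 holds the only proper number in this assay; the other value is a limit, (the limit of > 10000 nM in this assay, at which 1 of the 2 values shown sits). Among the compounds with values here, compound 1 and compound 2 differ in more than one place, so their pair gives no single step, and the two values show only that compound 1 has a number while compound 2 does not.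

The compound still to be measured is compound 3, `O=c1c(Cc2coc3cccc(OCC4CCCCC4)c3c2=O)coc2cc(Cl)ccc12`. It differs from compound 1 by a single change: chloro in place of hydrogen on an aromatic carbon. Within the data shown here, nothing among the measured compounds tells how this assay answers a change of that kind, since no pair differing in one place has been measured. The chloro group adds one heavy atom and nothing more, so the expected step is small, in no clear direction, and may well stay within the usual scatter. Compound 3 is therefore expected to give 3500 nM, with a range from 1000 nM to 10000 nM. The step this estimate means is a 1.2-fold lower number from compound 1 to compound 3 (0.08 log units; within the scatter).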

Compound 3, half-maximal inhibitory concentration: > 10000 nM
Compound 3: no number, only a limit (the forecaster's own chance of this, stated with the estimate: 20%); at least 2.8-fold (0.45 log units) between middle value and limit.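

Going by these compounds alone, this is the first pair in this assay that differs in one place, so it gives the first direct reading of a single change: chloro in place of hydrogen on an aromatic carbon, meta to a fused ring and para to a fused ring, brings an at least 2.3-fold higher number from compound 1 to compound 3 (0.37 log units; beyond the scatter). From the compounds shown here alone, compound 3 reaches only a limit of the assay, > 10000 nM, so the step is a lower bound on the loss and its full size stays unknown. One added chlorine at this position is therefore enough to turn the measurable number of compound 1 into a limit, and the limit now accounts for most of the values shown: the limit of > 10000 nM in this assay, at which 2 of the 3 values shown sit.

The compounds shown leave open whether this loss belongs to chloro itself or would follow from any group on this carbon, such as fluoro, a methoxy group or an amine. They also leave open whether chloro on another carbon of the same ring would give a number in this assay or the same limit.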